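Swapping methylsulfonyl for 1-hydroxyethyl on a stable compound

A few compounds are considered here, and "the series" means these few. Any claim that something is new, unique, unknown or untested is made for them only; others in the source may bear on it.

Compound 1 `COc1ccc(-c2cc(Cl)c3c(N)ncnn23)cc1N1CCN(C(C)=O)C(C)(C)C1=O` gives 94%
Compound 2 `CC(=O)N1CCN(c2cc(-c3cc(Cl)c4c(N)ncnn34)ccc2S(C)(=O)=O)C(=O)C1(C)C` gives 100%

In an ADME assay on microsomes from liver (Homo sapiens) for metabolic stability, read by LC-MS, using NADPH, with stated times of 6 min and 10 min, tested at 0.5 uM (a lower number here means that less of the compound is left, a higher number that more of the compound is left), compound 2 gives 100% at the very end of the scale, and compound 1 lies within the scatter of it. Compound 3 `CC(=O)N1CCN(c2cc(-c3cc(Cl)c4c(N)ncnn34)ccc2C(C)O)C(=O)C1(C)C` carries 1-hydroxyethyl in place of methylsulfonyl on an aromatic carbon. Within the data shown here, the only measured step touching this group is a number 6 percentage points higher from compound 1 to compound 2 (within the scatter) and it stayed small, yet no measured compound carries 1-hydroxyethyl. With compound 2 at 100% the number can only hold or fall in this assay so a moderate fall is expected. The estimated change is a drop (a number 12 percentage points lower from compound 2 to compound 3 (beyond the scatter)). For compound 3 the estimated value is 88% (expected range 68% to 100%).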

Compound 3, percent of the compound remaining: 100%
Estimate against measurement, compound 3: 12 percentage points below; the range from low to high includes it.
By their numbers in this assay, from the lowest: compounds 1, 2 and 3 (each within the scatter of the next).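

In this assay, putting 1-hydroxyethyl in place of methylsulfonyl gives no change at the digits printed from compound 2 to compound 3 (within the scatter), and putting it in place of methoxy gives a number 6 percentage points higher from compound 1 to compound 3 (within the scatter). This aromatic carbon has therefore carried three different groups, including 1-hydroxyethyl with its hydrogen-bond donor, and all three numbers stay within the scatter of one another. Nothing measured here explains this result. With compound 2 and compound 3 both at the very end of the scale, this read-out cannot separate them. From the compounds shown here alone, whether an amine or a carboxylic acid on this carbon would keep the number there remains open.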